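From bromo to propyl on the shared core

A few compounds are considered here, and "the series" means these few. Any claim that something is new, unique, unknown or untested is made for them only; others in the source may bear on it.

Measured in a functional assay on the whole organism (brain) with Mus musculus as the target; on this read-out higher numbers stand for an effect only at larger amounts of compound and lower numbers for an effect already at smaller amounts:
Compound 1 `O=[N+]([O-])c1ccc(OCCc2c[nH]cn2)cc1`: 0.66 mg/kg
Compound 2 `Brc1ccc(OCCc2c[nH]cn2)cc1`: 2.9 mg/kg

Compound 2 holds the higher of the two numbers in this assay, so it acts only at the larger dose. Among the compounds with values here, the single measured step, bromo in place of nitro on an aromatic carbon, is a 4.4-fold higher number from compound 1 to compound 2 (0.64 log units; beyond the scatter), a modest change beyond the scatter. The next compound is compound 3 `CCCc1ccc(OCCc2c[nH]cn2)cc1`, which differs from compound 2 as follows: propyl in place of bromo on an aromatic carbon. Within the data shown here, that measured step bears only loosely on this change, as it shares the bromo group but not the propyl group, and no measured compound carries propyl. The data therefore give no firm direction, and only a small shift is expected. The expected step is a 1.5-fold lower number from compound 2 to compound 3 (0.16 log units; within the scatter), which would remain within the scatter. Compound 3 is estimated at 2 mg/kg, with an expected range from 0.7 mg/kg to 6 mg/kg.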

Compound 3, dose for half-maximal effect: 1.6 mg/kg
Estimate against measurement, compound 3: 1.3-fold (0.10 log units) above, and the stated range covers the measured number.
By their numbers in this assay, from the lowest: compound 1; then compounds 3 and 2 (each within the scatter of the next).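

In this assay the exchange of bromo for propyl on the aromatic carbon para to a group of 8 heavy atoms gives a 1.8-fold lower number from compound 2 to compound 3 (0.26 log units; within the scatter) and so does not separate the two groups, although 3 heavy atoms of carbon replace 1 of bromine. Nitro stays apart from propyl as well, with a 2.4-fold higher number from compound 1 to compound 3 (0.38 log units; beyond the scatter) now standing alongside a 4.4-fold higher number from compound 1 to compound 2 (0.64 log units; beyond the scatter) and leaving compound 1 with the lowest number of the three. Nothing available explains why nitro differs from the other two groups.

The compounds shown leave open whether a longer chain than propyl would also stay level with bromo. They also leave open whether an amine or a carboxylic acid at this position would come closer to compound 1 .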